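Swapping a Hexyl Chain for a Halogenated Phenyl Ring

The compounds below may be only part of what the source reports. "The series", "measured", "known", "first", "only" and "open" are said of these compounds alone.

Compound 1, `CCCCCCNc1nc(SCc2ccc(C(F)(F)F)cc2)nc2ccccc12`, carries a hexyl chain on a nitrogen attached to its aromatic core. In a functional assay on HGC-27 cells (Homo sapiens) for cytotoxicity, read by MTT assay, with a stated time of 72 h (on this read-out lower numbers stand for stronger inhibition and higher numbers for weaker inhibition), compound 1 gives 23900 nM, the highest of the two numbers in hand. Two measured neighbours share the rest of the structure. Compound 3, `FC(F)(F)c1ccc(CSc2nc(Nc3cccc(C(F)(F)F)c3)c3ccccc3n2)cc1`, places a 3-(trifluoromethyl)phenyl on that nitrogen; in this assay compound 3 gives 11700 nM, and the step is a 2.0-fold lower number from compound 1 to compound 3 (0.31 log units; beyond the scatter). Compound 2, `CCOc1ccccc1Nc1nc(SCc2ccc(C(F)(F)F)cc2)nc2ccccc12`, carries a 2-ethoxyphenyl there instead; in this assay compound 2 reaches only the limit of > 50000 nM, which is the limit of > 50000 nM in this assay, at which 1 of the 3 values shown sits. The step is an at least 2.0-fold higher number from compound 1 to compound 2 (0.32 log units; beyond the scatter).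

Compound 4, `Fc1ccc(Nc2nc(SCc3ccc(C(F)(F)F)cc3)nc3ccccc23)cc1Cl`, is not yet measured. It differs from compound 1 in one place: 3-chloro-4-fluorophenyl in place of hexyl on a nitrogen on an aromatic ring. Like compound 3, it puts a substituted phenyl ring on that nitrogen, and that step was modest, so a step of similar size and direction is expected, while compound 2 shows that a phenyl ring can also push the number to the limit. For compound 4 in this assay the expected value is 12000 nM, in the range 5000 nM to 35000 nM. That amounts to an expected step of a 2.0-fold lower number from compound 1 to compound 4 (0.30 log units; within the scatter).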

Compound 4, half-maximal inhibitory concentration: 14700 nM
Compound 4: middle estimate off by 1.2-fold (0.09 log units), on the low side, and the stated range covers the measured number.
By their numbers in this assay, from the lowest: compounds 3, 4 and 1 (each within the scatter of the next, the first and the last beyond it). At a limit, above all of these: compound 2.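

In this assay, the change to 3-chloro-4-fluorophenyl gives a 1.6-fold lower number from compound 1 to compound 4 (0.21 log units; within the scatter), and the comparison with the other halogen-bearing ring gives a 1.3-fold higher number from compound 3 to compound 4 (0.10 log units; within the scatter), so neither pair can be told apart, even though compound 3 did separate from compound 1. Compound 4 does separate from the 2-ethoxyphenyl compound, with an at least 3.4-fold lower number from compound 2 to compound 4 (0.53 log units; beyond the scatter), showing that the choice of substituents on the phenyl ring can matter at this position. That step has no exact size, since compound 2 stands at a limit and not at a number: the limit of > 50000 nM in this assay, at which 1 of the 4 values shown sits.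

Going by these compounds, how a plain phenyl ring or a shorter butyl chain on that nitrogen would compare remains open. So does whether the result for compound 2 comes from the ethoxy group itself or from where it sits on the ring, which a methoxy group or a 4-ethoxyphenyl ring could help to settle.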